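Replacing the ethoxycarbonyl group of compound 2

The compounds below may be only part of what the source reports. "The series", "measured", "known", "first", "only" and "open" are said of these compounds alone.

Measured in a functional assay on HCT-116 cells (Homo sapiens) for inhibition, read by CCK-8 assay, with a stated time of 48 h; on this read-out lower numbers stand for stronger inhibition and higher numbers for weaker inhibition:
compound 1 `COc1ccc(-c2cc3nccc(-c4cc(OC)c(OC)c(OC)c4)n3n2)cc1`: 404 nM
compound 2 `CCOC(=O)c1ccc(-c2cc3nccc(-c4cc(OC)c(OC)c(OC)c4)n3n2)cc1`: > 10000 nM, a limit of the assay

Compound 2 has no exact place on the scale, its entry being (the limit of > 10000 nM in this assay, at which 1 of the 2 values shown sits). Compound 3 `COc1cc(-c2ccnc3cc(-c4ccc(-c5cnn(C)c5)cc4)nn23)cc(OC)c1OC` keeps the shared core and carries 1-methyl-1H-pyrazol-4-yl in place of ethoxycarbonyl on an aromatic carbon. Among the measured compounds shown here, one measured step bears on this change, made at the same place: an at least 24-fold higher number from compound 1 to compound 2 (1.39 log units; beyond the scatter). For the measured compounds named here, that step is large and shows that the group here can matter in this assay, but no compound with the incoming group has yet been measured. Going by the values given here, compound 1 gives 404 nM, the only exact value available, so a sizeable move towards lower numbers is expected. The expected change is an at least 6.6-fold lower number from compound 2 to compound 3 (0.82 log units; beyond the scatter). For compound 3 the estimated value is 1500 nM, with an expected range of 200 nM to 10000 nM.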

Compound 3, half-maximal inhibitory concentration: 2110 nM
Compound 3: middle estimate off by 1.4-fold (0.15 log units), on the low side; the measured number falls inside the stated range.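

In this assay, this aromatic carbon accepts a group bearing a five-membered aromatic ring and still gives an exact value: 1-methyl-1H-pyrazol-4-yl in place of ethoxycarbonyl gives an at least 4.7-fold lower number from compound 2 to compound 3 (0.67 log units; beyond the scatter). The entry for compound 2 is a limit, so this step fixes only a minimum size: the limit of > 10000 nM in this assay, at which 1 of the 3 values shown sits. Against methoxy, however, 1-methyl-1H-pyrazol-4-yl gives a 5.2-fold higher number from compound 1 to compound 3 (0.72 log units; beyond the scatter), which leaves compound 1 with the lowest number of the three and shows that the ring-bearing group recovers only part of the gap between the methoxy and ethoxycarbonyl compounds.

The compounds shown leave open how a carboxylic acid, a primary amide or a small amine would behave at this position. They also leave open whether a pyrazole lacking its methyl group would give a different number.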